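From 4-methoxyphenyl to 2-methylphenyl on the shared core

The source may report more compounds than this note shows. Statements on the series, on what has been measured and on what is new or still open speak of the compounds shown alone.

In a functional assay on K562 cells (Homo sapiens) for antiproliferative activity, with a stated time of 72 h (a higher number here means a weaker inhibitor, a lower number a stronger inhibitor), compound 1 `CCCCC#Cc1cc([C@@H]2O[C@H](CO)[C@@H](O)[C@H]2O)n2ncnc(N)c12` gives 2400 nM with its hex-1-yn-1-yl group. Compound 2 `Nc1ncnn2c([C@@H]3O[C@H](CO)[C@@H](O)[C@H]3O)cc(-c3ccc(F)cc3)c12` gives > 100000 nM as a limit of the assay and not as a number. Within the data shown here, compound 3 `COc1ccc(-c2cc([C@@H]3O[C@H](CO)[C@@H](O)[C@H]3O)n3ncnc(N)c23)cc1` gives 76400 nM as the higher of the two actual numbers, and compound 1 is its only numerical neighbour. Exchanging the alkyne for an aryl group gave large steps, with an at least 41-fold higher number from compound 1 to compound 2 (1.61 log units; beyond the scatter) and a 32-fold higher number from compound 1 to compound 3 (1.50 log units; beyond the scatter) both beyond the scatter. Between the two aryl compounds there is an at least 1.3-fold lower number from compound 2 to compound 3 (0.11 log units; that floor lies within the scatter) and that floor lies within the scatter. Compound 4 `Cc1ccccc1-c1cc([C@@H]2O[C@H](CO)[C@@H](O)[C@H]2O)n2ncnc(N)c12` differs from compound 3 as follows: 2-methylphenyl in place of 4-methoxyphenyl on an aromatic carbon with 2-methylphenyl in place of 4-methoxyphenyl on an aromatic carbon. It remains an aryl compound, so the small aryl-to-aryl step is the closest guide and not the large alkyne steps. No step beyond the scatter is therefore expected in this assay and a result at the assay limit is quite possible. The expected change is a 1.0-fold higher number from compound 3 to compound 4 (0.02 log units; within the scatter) by this estimate. Compound 4 is expected at 80000 nM with an estimated range from 30000 nM to 180000 nM in this reading.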

Compound 4, half-maximal inhibitory concentration: > 100000 nM
Compound 4: a limit, no number (the forecaster's own chance of this, stated with the estimate: 45%); middle value at least 1.2-fold (0.09 log units) away from the limit.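

In this assay, compound 4 extends the large loss seen on leaving the alkyne to a third aryl group, with an at least 41-fold higher number from compound 1 to compound 4 (1.61 log units; beyond the scatter), so the loss holds for 2-methylphenyl as well as for 4-fluorophenyl and 4-methoxyphenyl. Exchanging 4-methoxyphenyl for 2-methylphenyl gives an at least 1.3-fold higher number from compound 3 to compound 4 (0.11 log units; that floor lies within the scatter), and because the value of compound 4 is a limit of the assay and not a number, this step gives no order between the two compounds. The step between compound 2 and compound 4 cannot be read, and the assay limit caps the comparisons among the aryl compounds: the limit of > 100000 nM in this assay, at which 2 of the 4 values shown sit.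

The compounds shown leave open whether a saturated hexyl chain or a shorter alkyne such as prop-1-yn-1-yl on this carbon would stay near compound 1, which gives 2400 nM. They also leave open how the aryl compounds with limits would rank against each other.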